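This account rests on a few compounds, and the source may have more. Where it says the series, first, only, none or still open, it means among the compounds named here.

Compound 3, with the structure `COc1ccc(S(=O)(=O)NCCN2CCC(CCC(=O)c3cc(Cl)c(N)cc3OC)CC2)c(OC)c1`, gives 45% in an assay on HEK293 cells for displacement of a labelled ligand from 5-hydroxytryptamine receptor 6 (Homo sapiens), with a stated time of 60 min, tested at 1 uM, in the presence of a further agent that is not named here; on this read-out higher numbers stand for a stronger effect at the one concentration tested and lower numbers for a weaker effect. That puts it second of the three measured compounds: compound 2, the structure `COc1cc(N)c(Cl)cc1C(=O)CCC1CCN(CCNS(=O)(=O)c2ccc3c(c2)NC(=O)CO3)CC1`, gives 40%, a value within the scatter of compound 3, while compound 1, the structure `COc1ccc(S(=O)(=O)NCCN2CCC(CCC(=O)c3cc(Cl)c(N)cc3OC)CC2)cc1Cl`, gives 85%, the step of a number 40 percentage points lower from compound 1 to compound 3 (beyond the scatter) lying well beyond the scatter. Compound 4, with the structure `COc1cc(N)c(Cl)cc1C(=O)CCC1CCN(CCNS(=O)(=O)c2ccc(N)c(Br)c2)CC1`, has not yet been measured; the change from compound 3 is 4-amino-3-bromophenyl in place of 2,4-dimethoxyphenyl on a sulfonyl sulfur. The step of a number 40 percentage points lower from compound 1 to compound 3 (beyond the scatter) bears on it directly: compound 1, which carries a 3-chloro-4-methoxyphenyl on the sulfonyl sulfur, sits far above compound 3, and compound 4 returns to a halogenated phenyl with a single substituent at the 4-position. A step back upward is therefore expected, with a number 25 percentage points higher from compound 3 to compound 4 (beyond the scatter) the estimated size, though the step of a number 5 percentage points higher from compound 2 to compound 3 (within the scatter), within the scatter, shows not every change at this position moves the read-out. Compound 4 is therefore estimated to give 70%, with a range from 45% to 90%.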

Compound 4, a percentage reported as inhibition, at one concentration (the size of the read-out at that concentration, not a potency): 85%
Beside the measured number, compound 4's estimate is 15 percentage points below it; the range from low to high includes it.
By their numbers in this assay, from the lowest: compounds 2 and 3 (each within the scatter of the next); then compounds 1 and 4 (each within the scatter of the next).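

At the sulfonyl sulfur, the change gives a number 40 percentage points higher from compound 3 to compound 4 (beyond the scatter) and, on the second comparison, a number 45 percentage points higher from compound 2 to compound 4 (beyond the scatter), whereas 4-amino-3-bromophenyl in place of 3-chloro-4-methoxyphenyl gives no change at the digits printed from compound 1 to compound 4 (within the scatter). A high read-out at this position therefore does not require a methoxy group on the phenyl ring, and among these compounds the two groups carrying a halogen stand high, while the two without one stand low. No evidence is available to explain this. The compounds shown leave open whether the amino group or the bromine accounts for the step, and whether plain 4-aminophenyl or 3-bromophenyl would hold the high read-out.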